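Toxicity Check on a Side-Chain Swap at the Amide

The source may hold more compounds than are shown below. What is called first, only, known or untested is meant among the compounds shown, and "the series" means these compounds.

Compound 1, with the structure `Cc1cc(C)cc(S(=O)(=O)c2c(C(=O)NCc3cccc(N)c3)[nH]c3ccc(Cl)cc23)c1`, was tested in an ADME assay on MT4 cells (Homo sapiens) for cytotoxicity, read by MTT assay; on this read-out lower numbers stand for higher toxicity in this test and higher numbers for lower toxicity in this test. In this assay compound 1 gives > 53400 nM, which is a limit of the assay rather than a number. Two related compounds stand at limits of the same kind. Compound 2, `Cc1cc(C)cc(S(=O)(=O)c2c(C(=O)NC(C)c3cc(F)cc(F)c3)[nH]c3ccc(Cl)cc23)c1`, gives in this assay > 49700 nM, again a limit. Compound 3, `Cc1cc(C)cc(S(=O)(=O)c2c(C(=O)NCc3n[nH]c4ccccc34)[nH]c3ccc(Cl)cc23)c1`, gives in this assay > 50700 nM, also a limit. Each of the three values is a limit, as the limit of > 49700 nM in this assay, at which 1 of the 3 values shown sits, the limit of > 50700 nM in this assay, at which 1 of the 3 values shown sits, and the limit of > 53400 nM in this assay, at which 1 of the 3 values shown sits, show, so the steps between them cannot be read in size: a step that the two limits leave unreadable from compound 1 to compound 2, a step that the two limits leave unreadable from compound 1 to compound 3 and a step that the two limits leave unreadable from compound 2 to compound 3. Where compound 1 stands is thus known only as a limit, and the other two values are limits as well.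

Compound 4, `Cc1cc(C)cc(S(=O)(=O)c2c(C(=O)NCC(=O)NCc3ccccc3F)[nH]c3ccc(Cl)cc23)c1`, is not yet measured and differs from compound 1 by (2-fluorobenzyl)carbamoyl in place of 3-aminophenyl on a saturated chain carbon bound to an amide-type nitrogen. The three measured steps all change the group on the amide-type nitrogen, and none was readable, so none points to toxicity appearing in this assay. They bear on the new step only in that every such change so far left the value at a limit. The step expected is a step that the limit leaves unreadable from compound 1 to compound 4, meaning nothing readable beyond the scatter. Compound 4 is accordingly expected to give 60000 nM in this assay, with a range from 25000 nM to 200000 nM, most likely reported again as a limit.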

Compound 4, half-maximal cytotoxic concentration: > 47300 nM
Compound 4: only a limit was reported (the forecaster's own chance of this, stated with the estimate: 85%); the middle value is on the limit's open side.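

Compound 4 gives > 47300 nM in this assay, which is again a limit of the assay. Since the values of compound 1, compound 2 and compound 3 are limits too, none of the steps to compound 4 can be read in size. The compounds shown leave open at what concentration each would harm the cells, and whether the group on the amide-type nitrogen changes that.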